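Lengthening the chain by one carbon on compound 2

The compounds below may be only part of what the source reports. "The series", "measured", "known", "first", "only" and "open" are said of these compounds alone.

Compound 2 `N#C/N=C1\N(CCCCCOc2ccc(Cl)cc2)C(=O)CCN1c1ccncc1` and compound 1 `N#C/N=C1\N(CCCCCCOc2ccc(Cl)cc2)C(=O)CN1c1ccncc1` were both tested in a functional assay on HONE1 cells for cytotoxicity against HONE1 cell line (Homo sapiens); a higher number here means a weaker inhibitor, a lower number a stronger inhibitor. Compound 1 gives 2960 nM in this assay, and compound 2 gives 3450 nM; the two numbers sit within the scatter of each other, so neither compound can be called the stronger. Compound 2 holds the higher of the two numbers, with compound 1 nearest to it.

Compound 3 `N#C/N=C1\N(CCCCCCOc2ccc(Cl)cc2)C(=O)CCN1c1ccncc1` is compound 2 with one change: (4-chlorophenoxy)methyl in place of 4-chlorophenoxy on a saturated chain carbon, five bonds along the chain from an amide-type nitrogen in a ring. Compound 3 also carries the chain length of compound 1 together with the ring of compound 2. Within the data shown here, with no measured step of this kind available, and with compound 1 and compound 2 so close in this assay, no step beyond the scatter is expected from compound 2 to compound 3 in this assay, in either direction. Compound 3 is therefore estimated at 3200 nM in this assay, with a likely range from 1600 nM to 6400 nM, an expected step of a 1.1-fold lower number from compound 2 to compound 3 (0.03 log units; within the scatter).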

Compound 3, half-maximal inhibitory concentration: 577 nM
Estimate against measurement, compound 3: 5.5-fold (0.74 log units) above; measured number outside the range, below it.
By their numbers in this assay, from the lowest: compound 3; then compounds 1 and 2 (each within the scatter of the next).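

In this assay, a single added carbon on the saturated chain, (4-chlorophenoxy)methyl in place of 4-chlorophenoxy, gives a 6.0-fold lower number from compound 2 to compound 3 (0.78 log units; beyond the scatter), so this position responds strongly to a very small change. Chain length alone does not account for the result: with the same chain as compound 3 on a different core, compound 1 gives 2960 nM, whereas compound 3 gives 577 nM, so among the compounds shown the lower number appears only with this chain and this core together. Nothing available here bears on why the extra carbon has this effect.

As far as these compounds go, whether a still longer chain would lower the number further or raise it again remains open. From the compounds shown here alone, it is also open whether the gain would survive replacing the chlorine with another group, such as methoxy.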